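The source may report more compounds than this note shows. Statements on the series, on what has been measured and on what is new or still open speak of the compounds shown alone.

Compound 1 `CCOC(=O)c1cnc(NCc2ccccc2)nc1NCCCNC(=S)NCCC(=O)O` — limit only: > 600000 nM
Compound 2 `CCOC(=O)c1cnc(CCc2c[nH]c3ccccc23)nc1NCCCNC(=S)NCCC(=O)O` — limit only: > 600000 nM

In an assay on isolated protein for inhibition of NAD-dependent protein deacylase sirtuin-6 (Homo sapiens), in the presence of a further agent that is not named here (a lower number here means a stronger inhibitor, a higher number a weaker inhibitor), compound 1 gives only a limit, > 600000 nM. In this assay compound 2 also gives only a limit, > 600000 nM. Both sit at the limit of > 600000 nM in this assay, at which 2 of the 2 values shown sit, so the step that the two limits leave unreadable from compound 1 to compound 2 is not readable. Compound 3 `O=C(O)CCNC(=S)NCCCNc1nc(CCc2c[nH]c3ccccc23)ncc1C(=O)O` differs from compound 2 by hydrogen in place of ethyl on an oxygen next to a carbonyl group. No measured step touches this position, and the one step shown is unreadable, so nothing here sets a size or direction. Compound 3 is therefore expected to stay at the limit, with the estimated step that the limit leaves unreadable from compound 2 to compound 3. The estimate for compound 3 is 800000 nM, range 200000 nM to 3000000 nM.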

Compound 3, half-maximal inhibitory concentration: > 600000 nM
Compound 3: no number, only a limit; the forecaster's own chance of this, stated with the estimate: 85%; the middle value does not contradict the limit.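

The step between compound 2 and compound 3 cannot be read, since both give only limits in this assay: the limit of > 600000 nM in this assay, at which 3 of the 3 values shown sit.

The compounds shown leave open whether any change to this series gives a readable inhibition value, and which group would matter for it.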